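The source may hold more compounds than are shown below. What is called first, only, known or untested is meant among the compounds shown, and "the series" means these compounds.

Compound 1 `C=C(Br)C(=O)Nc1cccc(-c2cn3nc(-c4ccc(C)cc4)sc3n2)c1` gives 1700 nM in a functional assay on CCRF-CEM cells (Homo sapiens) for inhibition, read by cell counting, with a stated time of 3 days (a lower number here means a stronger inhibitor, a higher number a weaker inhibitor), the lower of the two numbers recorded there. Compound 2 `COc1ccc(-c2csc3nc(-c4cccc(N)c4)cn23)cc1` gives 6100 nM in this assay, a gap that lies beyond the usual scatter. Compound 3 `C=C(Br)C(=O)Nc1cccc(-c2cn3nc(-c4ccc(OC)cc4)sc3n2)c1` has not yet been measured; it differs from compound 1 by methoxy in place of methyl on an aromatic carbon. Among the compounds with values here, with no measured pair showing this change, only a small step is expected from compound 1 to compound 3, amounting to a 1.2-fold higher number from compound 1 to compound 3 (0.07 log units; within the scatter), which would not stand out from the scatter. Compound 3 is therefore estimated at 2000 nM, within a range from 800 nM to 5000 nM.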

Compound 3, half-maximal inhibitory concentration: 1200 nM
The estimate for compound 3 lay 1.7-fold (0.22 log units) above the measured number; low and high end bracket the measured number.
By their numbers in this assay, from the lowest: compounds 3 and 1 (each within the scatter of the next); then compound 2.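

Within the data shown here, exchanging 4-methylphenyl for 4-methoxyphenyl in this assay gives a 1.4-fold lower number from compound 1 to compound 3 (0.15 log units; within the scatter) and provides the first comparison between compounds differing in one place. At this position, para to a large group, methoxy and methyl therefore cannot be told apart in this read-out, even though methoxy adds one heavy atom and one hydrogen-bond acceptor. Nothing available explains this result.

Going by these compounds, whether an amine, a carboxylic acid or a longer chain at this position would shift the number beyond the scatter remains open.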